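Aryl variation on the shared core, compound 4 expected

The source may hold more compounds than are shown below. What is called first, only, known or untested is meant among the compounds shown, and "the series" means these compounds.

Three aryl variants of one shared core have been measured in an assay on isolated protein for inhibition of acid ceramidase (Homo sapiens), read by LC-MS, with a stated time of 1 h; a higher number here means a weaker inhibitor, a lower number a stronger inhibitor. Compound 1 `O=C(NCCCCc1ccccc1)n1cc(-c2ccc(F)cc2)oc1=O` gives 185 nM. Compound 2 `COc1cccc(-c2cn(C(=O)NCCCCc3ccccc3)c(=O)o2)c1` gives 341 nM. Compound 3 `COc1ccccc1-c1cn(C(=O)NCCCCc2ccccc2)c(=O)o1` gives 177 nM. Among the measured compounds shown here, compound 3 sits at the low end of these three numbers, yet no pair of them is separated beyond the scatter: a 1.0-fold lower number from compound 1 to compound 3 (0.02 log units; within the scatter) and a 1.9-fold lower number from compound 2 to compound 3 (0.28 log units; within the scatter).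

Compound 4 `COc1cc(-c2cn(C(=O)NCCCCc3ccccc3)c(=O)o2)ccc1F` is not yet measured. Relative to compound 3 the change is 4-fluoro-3-methoxyphenyl in place of 2-methoxyphenyl on an aromatic carbon. For the measured compounds named here, two measured steps bear on it. The exchange of 4-fluorophenyl for 3-methoxyphenyl gave a 1.8-fold higher number from compound 1 to compound 2 (0.27 log units; within the scatter), and the exchange of 3-methoxyphenyl for 2-methoxyphenyl gave a 1.9-fold lower number from compound 2 to compound 3 (0.28 log units; within the scatter). Compound 4 carries both the fluorine seen in compound 1 and the methoxy seen in compound 2 on one ring, and every aryl change so far has stayed within the scatter. A step no larger than the scatter is therefore expected in this assay, if anything toward a higher number, because the move from 3-methoxyphenyl to 2-methoxyphenyl gave a 1.9-fold lower number from compound 2 to compound 3 (0.28 log units; within the scatter) in the opposite sense. The expected step is a 1.5-fold higher number from compound 3 to compound 4 (0.17 log units; within the scatter). For compound 4 the estimate in this assay is 260 nM, with a range from 120 nM to 560 nM.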

Compound 4, half-maximal inhibitory concentration: 80 nM
Compound 4: the middle estimate sits 3.3-fold (0.51 log units) above what was measured, and the stated range ends above it.
By their numbers in this assay, from the lowest: compound 4; then compounds 3, 1 and 2 (each within the scatter of the next).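

In this assay, among the compounds shown here, the aryl group on the shared core is the first place to give steps beyond the scatter, and both come from adding one group to a ring that already carries the other: fluoro in place of hydrogen on the ring of compound 2 (a 4.3-fold lower number from compound 2 to compound 4 (0.63 log units; beyond the scatter)) and methoxy in place of hydrogen on the ring of compound 1 (a 2.3-fold lower number from compound 1 to compound 4 (0.36 log units; beyond the scatter)). The 4-fluoro-3-methoxyphenyl group also separates from 2-methoxyphenyl (a 2.2-fold lower number from compound 3 to compound 4 (0.34 log units; beyond the scatter)), so this position responds to aryl substitution even though the three singly substituted rings stayed within the scatter of one another. Nothing available explains why the two groups on one ring give a lower number than either ring alone.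

Still open, going by these compounds, is whether the lower number depends on these two groups specifically, which could be tested by a chloro in place of the fluoro or a hydroxy in place of the methoxy. On these data alone, the phenyl-ended chain is also unchanged across all four compounds, so it remains unknown whether the same aryl step would hold with a shorter chain or with an amine in that chain.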